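The compounds below may be only part of what the source reports. "The series", "measured", "known", "first", "only" and "open" are said of these compounds alone.

Compound 3 `CCOc1ccccc1-c1ccc(-c2nc3cnccc3c(C[C@H](C)C(=O)O)c2C#N)cc1` belongs to a set of three compounds that share one core and differ only in a single group on an aromatic carbon. In a physicochemical assay for lipophilicity, read by HPLC, at pH 7.5 (on this read-out lower numbers stand for lower lipophilicity and higher numbers for higher lipophilicity), compound 3 gives 2.2, the second highest of the three numbers. Compound 1 `CCOc1ccccc1-c1ccc(-c2nc3cnccc3cc2C#N)cc1`, which carries hydrogen at that carbon, gives 3.8, and compound 2 `CCOc1ccccc1-c1ccc(-c2nc3cnccc3c(NC(C)C(=O)O)c2C#N)cc1`, which carries a (1-carboxyethyl)amino group there, gives 2.1. The measured steps run a number 1.70 log units lower from compound 1 to compound 2 (beyond the scatter) and a number 1.60 log units lower from compound 1 to compound 3 (beyond the scatter), whereas a number 0.10 log units higher from compound 2 to compound 3 (within the scatter). Compound 4 `CCOc1ccccc1-c1ccc(-c2nc3cnccc3c(N[C@H](CC)C(=O)NS(C)(=O)=O)c2C#N)cc1` has not yet been measured. On going from compound 3 to compound 4, (a group of 11 heavy atoms (5 carbon, 2 nitrogen, 3 oxygen, 1 sulfur; no ring) in place of a group of 6 heavy atoms (4 carbon, 2 oxygen; no ring), on an aromatic carbon). Among the compounds with values here, both measured steps that replaced hydrogen by a larger group lowered the number by a large amount, and the one step between two substituted compounds stayed within the scatter, so the change from compound 3 to compound 4 has only indirect precedent. A small step is therefore expected, a number 0.10 log units higher from compound 3 to compound 4 (within the scatter). Compound 4 is estimated at 2.3, with a range from 1.7 to 2.9.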

Compound 4, distribution coefficient: 2.2
For compound 4 the middle estimate is 0.10 log units above the measured one; measured number inside the range.
By their numbers in this assay, from the lowest: compounds 2, 3 and 4 (each within the scatter of the next); then compound 1.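

In this assay, the carbon opposite the ring nitrogen takes a group of 11 heavy atoms that has no carboxy end, and the read-out stays level with the two carboxy compounds: no change at the digits printed from compound 3 to compound 4 (within the scatter), and a number 0.10 log units higher from compound 2 to compound 4 (within the scatter). The gap to the hydrogen compound also holds for this new group, at a number 1.60 log units lower from compound 1 to compound 4 (beyond the scatter), so three different groups now sit together, well apart from hydrogen. Nothing shown here explains this clustering.

On these data alone, it remains open whether a plain amine or a longer carbon chain at this carbon, with neither a carboxylic acid nor a sulfonyl group at its end, would read close to these three or close to compound 1. As far as these compounds go, the opposite configuration at the defined stereocentre of compound 4 also remains open.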